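The source may report more compounds than this note shows. Statements on the series, on what has been measured and on what is new or still open speak of the compounds shown alone.

Measured so far in an assay on CHO cells for displacement of a labelled ligand from adenosine receptor A1 (Homo sapiens); a lower number here means a stronger inhibitor, a higher number a weaker inhibitor:
compound 1 `Cc1ccc(CNc2ncc(C(=O)O)c3nc(-c4ccco4)nn23)cc1`: 2730 nM
compound 2 `O=C(O)c1cnc(NCc2ccc(F)cc2)n2nc(-c3ccco3)nc12`: > 100000 nM, a limit of the assay

Compound 1 gives 2730 nM in this assay. Compound 2 reaches only the limit > 100000 nM in this assay, so no number is known for it. Going by the values given here, the single step between the measured compounds, fluoro in place of methyl on an aromatic carbon, runs an at least 36-fold higher number from compound 1 to compound 2 (1.56 log units; beyond the scatter); the fluoro compound sits at the limit of > 100000 nM in this assay, at which 1 of the 2 values shown sits.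

Compound 3 `O=C(O)c1cnc(NCc2ccc(C(F)(F)F)cc2)n2nc(-c3ccco3)nc12` is not yet measured in this assay. It differs from compound 2 by trifluoromethyl in place of fluoro on an aromatic carbon of a six-membered aromatic ring of carbon only, para to a large group. Among the compounds with values here, the only measured step touching this position is an at least 36-fold higher number from compound 1 to compound 2 (1.56 log units; beyond the scatter), which shows that exchanging the group at this carbon can move the number far. Compound 2 stands at the limit, so any step from it can only be a return into the measurable range or none at all. The step expected here is an at least 3.3-fold lower number from compound 2 to compound 3 (0.52 log units; beyond the scatter), with a real chance that another limit is all that comes back. The estimate for compound 3 is 30000 nM, range 5000 nM to 100000 nM.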

Compound 3, inhibition constant: > 100000 nM
Compound 3 gave a limit, no number; the forecaster's own chance of this, stated with the estimate: 45%; middle value at least 3.3-fold (0.52 log units) from the limit.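

In this assay, trifluoromethyl now joins fluoro as a second replacement for methyl on this aromatic carbon, and it too gives an at least 36-fold higher number from compound 1 to compound 3 (1.56 log units; beyond the scatter). The loss of a readable value is therefore not particular to fluoro, and among the three compounds only the methyl compound, compound 1, gives a number, with neither compound 2 nor compound 3 going against this. The step between compound 2 and compound 3 cannot be read, and the larger trifluoromethyl group, with its 4 heavy atoms against 1 for fluoro, cannot be ranked against fluoro, because both values rest on the same limit of the assay: the limit of > 100000 nM in this assay, at which 2 of the 3 values shown sit.

Going by these compounds alone, it remains open whether methyl is the only group at this carbon that keeps a measurable value, or whether an ethyl, a methoxy or a chlorine in its place would also do so. On these data alone, it is equally open whether an amide in place of the carboxylic acid on the shared core would bring the fluoro or trifluoromethyl compounds back into the measurable range.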